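A few compounds are considered here, and "the series" means these few. Any claim that something is new, unique, unknown or untested is made for them only; others in the source may bear on it.

Measured compounds:
compound 1 `COc1ccc(S(=O)(=O)N2CCc3cccc(NC(=O)c4ccc(F)cc4)c32)cc1` – 93 nM
compound 2 `COc1ccc(S(=O)(=O)N2CCc3cccc(N)c32)cc1` – 2800 nM

In a functional assay on KB cells (Homo sapiens) for cytotoxicity (on this read-out lower numbers stand for stronger inhibition and higher numbers for weaker inhibition), compound 1 holds the lowest number of the two measured. For the measured compounds named here, the only measured step, a 30-fold higher number from compound 1 to compound 2 (1.48 log units; beyond the scatter), concerns loss of the whole acyl group and does not directly address the change to compound 3 `COc1ccc(S(=O)(=O)N2CCc3cccc(NC(=O)c4ccc(C#N)cc4)c32)cc1`, which keeps that group and alters only its substituent: cyano in place of fluoro on an aromatic carbon. Going by the values given here, with no measured step touching this substituent, no step beyond the scatter is expected in this assay; the estimate for compound 3 is 90 nM, range 30 nM to 300 nM, meaning a 1.0-fold lower number from compound 1 to compound 3 (0.01 log units; within the scatter).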

Compound 3, half-maximal inhibitory concentration: 105 nM
The estimate for compound 3 lay 1.2-fold (0.07 log units) below the measured number; low and high end bracket the measured number.
By their numbers in this assay, from the lowest: compounds 1 and 3 (each within the scatter of the next); then compound 2.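

In this assay, with the substituent on an aromatic carbon para to a large group, cyano in place of fluoro gives a 1.1-fold higher number from compound 1 to compound 3 (0.05 log units; within the scatter), so the two groups cannot be told apart at this position on this read-out. The large acyl step also holds with the new group, at a 27-fold lower number from compound 2 to compound 3 (1.43 log units; beyond the scatter), so it appears with cyano as well as with fluoro. Nothing available bears on why the two substituents read alike.

As far as these compounds go, whether an amine, a carboxylic acid or a methoxy group at this position would also read alike stays open. So does how the unsubstituted phenyl carbonyl amide would read.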